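A few compounds are considered here, and "the series" means these few. Any claim that something is new, unique, unknown or untested is made for them only; others in the source may bear on it.

Measured in an ADME assay on MDBK cells (Bos taurus) for cytotoxicity; a higher number here means that more compound is tolerated, a lower number that less compound is tolerated:
- compound 1 `Fc1cccc(F)c1Cn1ccc2nc(-c3ccccc3)nc-2c1`: > 100000 nM, a limit of the assay.
- compound 2 `Clc1ccc(Cn2ccc3nc(-c4ccccc4)nc-3c2)cc1`: > 100000 nM, a limit of the assay.
- compound 3 `Brc1cccc(Cn2ccc3nc(-c4ccccc4)nc-3c2)c1`: 85000 nM.

Among the measured compounds shown here, compound 3 gives the only actual number in the set at 85000 nM. The rest of the evidence is the limit of > 100000 nM in this assay, at which 2 of the 3 values shown sit.

The next structure is compound 4 `c1ccc(CCCn2ccc3nc(-c4ccccc4)nc-3c2)cc1`, which has phenethyl in place of 3-bromophenyl on a saturated chain carbon bound to an aromatic nitrogen. The bromine leaves, and one six-membered aromatic ring of carbon only remains in the group.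

The measured steps that bear on this change all swap the group at that same place. They are an at least 1.1-fold lower number from compound 1 to compound 3 (0.07 log units; that floor lies within the scatter) and an at least 1.1-fold lower number from compound 2 to compound 3 (0.07 log units; that floor lies within the scatter). The third, a step that the two limits leave unreadable from compound 1 to compound 2, adds no size. None of these steps brings in phenethyl, so the read-across is indirect. Across the three groups measured, this assay shows no step that can be read as beyond the scatter.

No step beyond the scatter is therefore expected in this assay, and no direction can be favoured. The expected change is a 1.1-fold higher number from compound 3 to compound 4 (0.02 log units; within the scatter). The estimate for compound 4 is 90000 nM, with an expected range from 45000 nM to 170000 nM. A report of only a limit would be no surprise.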

Compound 4, half-maximal cytotoxic concentration: > 100000 nM
Compound 4: a limit, no number; the forecaster's own chance of this, stated with the estimate: 50%; middle value at least 1.1-fold (0.04 log units) from the limit.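

In this assay compound 4 gives > 100000 nM, a limit of the assay and not a number. Among the compounds shown here, the one readable step is an at least 1.1-fold higher number from compound 3 to compound 4 (0.07 log units; that floor lies within the scatter), while the steps to compound 4 from compound 1 and compound 2 cannot be read, as both ends of each are limits. Phenethyl is the first group in the series without a halogen at this place, on a saturated chain carbon bound to an aromatic nitrogen, and it adds no readable change to the picture from the three halogen-bearing groups, so compound 3 remains the only compound with an actual number and the series is still described mainly by: the limit of > 100000 nM in this assay, at which 3 of the 4 values shown sit.

Going by these compounds, how far compound 1, compound 2 and compound 4 lie past that limit stays open, so no order among them or against compound 3 can be given. On these data alone, it also stays open whether any group at this place can bring the number clearly down in this assay, for instance an amine, a carboxylic acid or a chain longer than phenethyl.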